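Trifluoromethoxy in place of trifluoromethyl on compound 2

The source may report more compounds than this note shows. Statements on the series, on what has been measured and on what is new or still open speak of the compounds shown alone.

Compound 1 `Oc1cccc(-c2cc(-c3ccccc3F)cc(-c3cccc(O)c3)n2)c1` gives 11200 nM in a functional assay on DU-145 cells (Homo sapiens) for inhibition; on this read-out higher numbers stand for weaker inhibition and lower numbers for stronger inhibition.
Compound 2 `Oc1cccc(-c2cc(-c3cccc(C(F)(F)F)c3)cc(-c3cccc(O)c3)n2)c1` reaches only the assay limit of > 50000 nM in this assay.
Compound 3 `Oc1ccc(-c2cc(-c3cccc(C(F)(F)F)c3)cc(-c3cccc(O)c3)n2)cc1` gives 11100 nM in this assay.

Compound 2 stands weakest of the three; its value is a limit, not a number, so only a floor is known (the limit of > 50000 nM in this assay, at which 1 of the 3 values shown sits). Compound 4 `Oc1cccc(-c2cc(-c3cccc(OC(F)(F)F)c3)cc(-c3cccc(O)c3)n2)c1` differs from compound 2 by trifluoromethoxy in place of trifluoromethyl on an aromatic carbon. Within the data shown here, no measured step alters that group directly. The nearest guide is an at least 4.4-fold higher number from compound 1 to compound 2 (0.64 log units; beyond the scatter), showing that a change at this position can move the number beyond the scatter, while an at least 4.5-fold lower number from compound 2 to compound 3 (0.65 log units; beyond the scatter) shows a step of similar size from a change elsewhere. With trifluoromethoxy untested, compound 4 is expected to remain close to the limit. The estimate for compound 4 is 45000 nM, ranging from 12000 nM to 100000 nM. The expected step is an at least 1.1-fold lower number from compound 2 to compound 4 (0.04 log units; that floor lies within the scatter).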

Compound 4, half-maximal inhibitory concentration: > 50000 nM
Compound 4: no number, only a limit (the forecaster's own chance of this, stated with the estimate: 55%); middle value at least 1.1-fold (0.04 log units) from the limit.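

In this assay compound 4, like compound 2, gives only a limit and not a number, so the step from trifluoromethyl to trifluoromethoxy cannot be read: the limit of > 50000 nM in this assay, at which 2 of the 4 values shown sit.

As far as these compounds go, how far past that limit compound 2 and compound 4 lie, and whether the two groups differ at all, stays open.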